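Piperidine sulfonamides: configuration at the hydroxyl-bearing ring carbon

The compounds below may be only part of what the source reports. "The series", "measured", "known", "first", "only" and "open" are said of these compounds alone.

Measured compounds:
- compound 1 `CCOC(=O)[C@@H]1C[C@H](O)CN(S(=O)(=O)c2ccc(S(=O)(=O)N(CC)CC)cc2)C1`: 300 nM
- compound 2 `CCN(CC)C(=O)[C@@H]1CCCN(S(=O)(=O)c2ccc(S(=O)(=O)N(CC)CC)cc2)C1`: 700 nM
- compound 3 `CCN(CC)S(=O)(=O)c1ccc(S(=O)(=O)N2CCC[C@@H](C(=O)N3CC4(CCN(C(=O)OC(C)(C)C)C4)C3)C2)cc1`: 1300 nM

In a functional assay on MIA PaCa-2 cells (Homo sapiens) for inhibition, read by MTT assay, with a stated time of 3 days (on this read-out higher numbers stand for weaker inhibition and lower numbers for stronger inhibition), compound 1 gives 300 nM, the lowest of the three numbers recorded. The nearest number belongs to compound 2, whose value lies beyond the scatter above that of compound 1, and compound 3 lies further still. The three compounds differ in several places at once, so no single change can be read from them.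

Compound 4 `CCOC(=O)[C@@H]1C[C@@H](O)CN(S(=O)(=O)c2ccc(S(=O)(=O)N(CC)CC)cc2)C1` is the untested member. Relative to compound 1 the difference is: the two compounds have the same atoms and bonds and differ only in configuration as drawn: 1 of 2 stereo elements differ; a stereocentre at a saturated ring carbon is drawn S in compound 1 and R in compound 4. For the measured compounds named here, no measured pair in the set differs only in configuration, so the set gives no yardstick for a step of this kind. The step from compound 1 to compound 4 is expected to be a 1.7-fold higher number from compound 1 to compound 4 (0.22 log units; within the scatter), a modest weakening at most and possibly no change beyond the scatter. Compound 4 is therefore estimated at 500 nM, with a likely range from 150 nM to 1500 nM.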

Compound 4, half-maximal inhibitory concentration: 2100 nM
For compound 4 the middle estimate is 4.2-fold (0.62 log units) below the measured one; the whole stated range lies below it.
By their numbers in this assay, from the lowest: compound 1; then compounds 2, 3 and 4 (each within the scatter of the next, the first and the last beyond it).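

In this assay, inverting only the stereocentre at a saturated ring carbon, from S to R, gives a 7.0-fold higher number from compound 1 to compound 4 (0.85 log units; beyond the scatter). For the compounds shown here, this position is therefore sensitive to configuration, which the earlier compounds could not show, as they differ in several places at once. The gap can be assigned to configuration alone, because atoms and bonds stay the same: the fact that compounds 1 and 4 differ only in the configuration as drawn

The compounds shown do not tell whether the S form keeps its advantage when the ethyl ester is replaced by a carboxylic acid or the hydroxyl by a methoxy group. They also leave open what the second stereocentre contributes, as its configuration is the same in compound 1 and compound 4.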